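Swapping the Aryl Amine on Compound 2: Expected Effect

The compounds below may be only part of what the source reports. "The series", "measured", "known", "first", "only" and "open" are said of these compounds alone.

Compound 2 `COc1cc(NC(=O)Nc2cc(Nc3ccc(F)c(Cl)c3)ncn2)cc(OC)c1` stands lowest of the three measured compounds in a functional assay on NCI-H520 cells (Homo sapiens) for inhibition, read by MTT assay, with a stated time of 48 h, tested at 10 uM (a higher number here means more inhibition at the concentration tested (going by the name of the read-out), a lower number less inhibition), giving 25.5%. Compound 3 `COc1cc(Br)ccc1Nc1cc(NC(=O)Nc2c(Cl)cccc2Cl)ncn1` sits nearest to it with 29.1%, a gap that is within the scatter, while compound 1 `Cc1cc(F)cc(Nc2cc(NC(=O)Nc3c(Cl)cccc3Cl)ncn2)c1` is furthest away with 60.5%, beyond the scatter. The unmeasured compound 4 `COc1cc(NC(=O)Nc2cc(Nc3cc(I)ccc3OC)ncn2)cc(OC)c1` differs from compound 2 in one place: 5-iodo-2-methoxyphenyl in place of 3-chloro-4-fluorophenyl on a nitrogen on an aromatic ring. Going by the values given here, the only measured step at the same position is the change from compound 1 to compound 3, where a related aryl carrying a methoxy and a halogen entered and the value fell by a number 31.4 percentage points lower from compound 1 to compound 3 (beyond the scatter), although the remainder of those two structures differs from that of compound 2. Since compound 2 already shows little inhibition and compound 3, which bears the closer aryl, gives 29.1%, no step beyond the scatter is expected. Compound 4 is therefore estimated at 23%, in a range from 8% to 40%, which means an expected step of a number 2.5 percentage points lower from compound 2 to compound 4 (within the scatter).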

Compound 4, a percentage reported as inhibition, at one concentration (the size of the read-out at that concentration, not a potency): 55%
Estimate against measurement, compound 4: 32 percentage points below; measured number outside the range, above it.
By their numbers in this assay, from the lowest: compounds 2 and 3 (each within the scatter of the next); then compounds 4 and 1 (each within the scatter of the next).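

In this assay, the position on the nitrogen can carry a large change in the setting of compound 2 as well, with a number 29.5 percentage points higher from compound 2 to compound 4 (beyond the scatter). Going by these compounds alone, the only earlier step at this position ran the other way, a number 31.4 percentage points lower from compound 1 to compound 3 (beyond the scatter), so an aryl bearing a methoxy and a halogen does not lower the number in every setting; the two steps differ in the groups that enter and leave and in the rest of the structure, so the compounds cannot show which of these sets the direction. No measurement given here bears on why the number rose with 5-iodo-2-methoxyphenyl.

The compounds shown do not separate the share of the iodine from that of the methoxy in this step. On these data alone, how a phenyl ring carrying an amine or a carboxylic acid would read at this position also remains open.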